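The compounds below may be only part of what the source reports. "The series", "measured", "known", "first", "only" and "open" are said of these compounds alone.

The shared core of compound 1 `CCn1c(C(=O)N[C@@H](C)CO)ccc1C(CC)(CC)c1ccc(OCS(=O)(=O)c2ccccc2)c(C)c1` carries, on an amide-type nitrogen, a 1-(hydroxymethyl)ethyl group. In a functional assay on PC-3 cells (Homo sapiens) for antiproliferative activity, read by MTT assay, with a stated time of 24 h (a higher number here means a weaker inhibitor, a lower number a stronger inhibitor), compound 1 gives 9520 nM, the second highest of the three numbers measured. Compound 2 `CCn1c(C(=O)NC2(CO)CC2)ccc1C(CC)(CC)c1ccc(OCS(=O)(=O)c2ccccc2)c(C)c1`, which puts a 1-(hydroxymethyl)cyclopropyl on the same nitrogen, gives 3560 nM, and compound 3 `CCn1c(C(=O)N[C@@H](CO)CCO)ccc1C(CC)(CC)c1ccc(OCS(=O)(=O)c2ccccc2)c(C)c1`, with a 3-hydroxy-1-(hydroxymethyl)propyl there, gives 14100 nM.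

Compound 4 `CCn1c(C(=O)NCC(=O)O)ccc1C(CC)(CC)c1ccc(OCS(=O)(=O)c2ccccc2)c(C)c1` changes the same place: carboxymethyl in place of 1-(hydroxymethyl)ethyl on an amide-type nitrogen. Within the data shown here, the group that enters, carboxymethyl, is new to this set, so no measured step covers it directly. Among the measured compounds shown here, the steps that bear on it are the two earlier swaps at this nitrogen. Going to the ring-bearing group gave a 2.7-fold lower number from compound 1 to compound 2 (0.43 log units; beyond the scatter), and adding a second hydroxyl-bearing arm gave a 1.5-fold higher number from compound 1 to compound 3 (0.17 log units; within the scatter). Both changes at this position moved the number only modestly, in opposite directions, and the larger, more polar group in compound 3 did not help.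

On that basis compound 4 is expected to stay close to compound 1 or drift toward a somewhat weaker result, so the estimated step is a 1.4-fold higher number from compound 1 to compound 4 (0.14 log units; within the scatter). The estimate for compound 4 in this assay is 13000 nM, within a range from 5000 nM to 35000 nM.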

Compound 4, half-maximal inhibitory concentration: 30100 nM
Compound 4: the middle estimate sits 2.3-fold (0.36 log units) below what was measured, and the stated range covers the measured number.
By their numbers in this assay, from the lowest: compound 2; then compounds 1 and 3 (each within the scatter of the next); then compound 4.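

In this assay, carboxymethyl has the same heavy-atom count as 1-(hydroxymethyl)ethyl, yet the swap gives a 3.2-fold higher number from compound 1 to compound 4 (0.50 log units; beyond the scatter) and so shows that this amide-type nitrogen responds to the make-up of its group, not only to the group's size. Compound 4 is also separated beyond the scatter from the other two compounds, with a 2.1-fold higher number from compound 3 to compound 4 (0.33 log units; beyond the scatter) and an 8.5-fold higher number from compound 2 to compound 4 (0.93 log units; beyond the scatter) as the widest gap yet seen at this nitrogen, which makes compound 4 the weakest of the four in this assay. Nothing shown here gives a measured explanation for these differences.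

The swap also removes the defined stereocentre of compound 1, so the compounds shown leave open how much of the step comes from that loss and how much from the carboxylic acid itself. Also unsettled is whether a methyl ester or a primary amide in place of the acid, a longer chain ending in the same acid, or an amine at the end of such a chain would bring the number back toward that of compound 1 or compound 2.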